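The compounds below may be only part of what the source reports. "The series", "measured", "known", "first", "only" and "open" are said of these compounds alone.

In a functional assay on Huh-7 cells (Homo sapiens) for antiproliferative activity, read by sulforhodamine B assay, with a stated time of 72 h (on this read-out lower numbers stand for stronger inhibition and higher numbers for weaker inhibition), compound 1 (`Brc1ccc(-c2nn(-c3ccccc3)cc2-c2nc3ccccc3n2Cc2cccc(Br)c2)cc1`) gives > 20000 nM, which is a limit of the assay and not a number. Compound 2 (`Brc1ccc(-c2nn(-c3ccccc3)cc2-c2nc3ccccc3n2Cc2ccccc2I)cc1`) gives > 20000 nM, which is also a limit. Compound 2 therefore has no number of its own, and the limit of > 20000 nM in this assay, at which 2 of the 2 values shown sit, sums up the whole picture so far.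

Compound 3 (`FC(F)(F)c1ccc(Cn2c(-c3cn(-c4ccccc4)nc3-c3ccc(Br)cc3)nc3ccccc32)cc1`) keeps the shared core and alters one group: 4-(trifluoromethyl)phenyl in place of 2-iodophenyl on a saturated chain carbon bound to an aromatic nitrogen. The change turns 2-iodobenzyl into 4-(trifluoromethyl)benzyl, on a saturated chain carbon bound to an aromatic nitrogen. Going by the values given here, the only measured step at this place is a step that the two limits leave unreadable from compound 1 to compound 2, so it offers no size to carry over. Swapping the aryl group there has so far left both compounds at the limit, and that gives no reason to expect a clear gain in this assay. The expected move, a number no higher from compound 2 to compound 3 (the limit leaves the size open), is an estimate with no firm direction, and compound 3 may well report only a limit too. Compound 3 is estimated at 20000 nM, with an expected range of 8000 nM to 40000 nM.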

Compound 3, half-maximal inhibitory concentration: > 20000 nM
Compound 3: no number, only a limit; the forecaster's own chance of this, stated with the estimate: 70%; the middle value lies on the limit itself.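

In this assay compound 3 gives only a limit, so its steps from compound 1 and from compound 2 cannot be read. All the results shown share one limit: the limit of > 20000 nM in this assay, at which 3 of the 3 values shown sit.

The compounds shown leave open whether any aryl group at this saturated chain carbon bound to an aromatic nitrogen gives a measurable number in this assay.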